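Hydroxy in place of bromo: notes on the series

The source may report more compounds than this note shows. Statements on the series, on what has been measured and on what is new or still open speak of the compounds shown alone.

Measured so far in a functional assay on HepG2 cells (Homo sapiens) for inhibition, read by MTT assay, with a stated time of 72 h; on this read-out lower numbers stand for stronger inhibition and higher numbers for weaker inhibition
- compound 1 `C#CCSc1nc(Nc2ccc(Cl)cc2)c2ccncc2n1` gives 36700 nM
- compound 2 `C#CCSc1nc(Nc2cccc(Cl)c2)c2ccncc2n1` gives 1090 nM
- compound 3 `C#CCSc1nc(Nc2ccc(Br)cc2)c2ccncc2n1` gives 56200 nM

Compound 3 stands at the high end of these numbers. Its nearest neighbour gives a 1.5-fold higher number from compound 1 to compound 3 (0.19 log units; within the scatter) and its furthest gives a 52-fold higher number from compound 2 to compound 3 (1.71 log units; beyond the scatter), so the set splits into one low value and two that cannot be told apart.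

Compound 4 `C#CCSc1nc(Nc2ccc(O)cc2)c2ccncc2n1` differs from compound 3 by hydroxy in place of bromo on an aromatic carbon, with hydroxy in place of bromo on an aromatic carbon, para to a large group. Among the compounds with values here, no measured step makes this exchange, so the evidence is indirect. The closest guide is a 1.5-fold higher number from compound 1 to compound 3 (0.19 log units; within the scatter), where one group replaced another at this same place. Within the data shown here, the large steps, a 34-fold lower number from compound 1 to compound 2 (1.53 log units; beyond the scatter) and the one to compound 3 noted above, both involve moving away from the 3-chlorophenyl pattern, and compound 4 keeps its group where compound 3 has it. As far as these compounds go, a step beyond the scatter is therefore not expected, although the hydroxy group is untested here and the range stays wide. The expected step is a 1.6-fold lower number from compound 3 to compound 4 (0.21 log units; within the scatter) in this assay as estimated. For compound 4 the estimate is 35000 nM, with an expected range of 8000 nM to 100000 nM in this read-out.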

Compound 4, half-maximal inhibitory concentration: > 80000 nM
Compound 4 gave a limit, no number; the forecaster's own chance of this, stated with the estimate: 15%; at least 2.2-fold (0.35 log units) between middle value and limit.
By their numbers in this assay, from the lowest: compound 2; then compounds 1 and 3 (each within the scatter of the next). At a limit, above all of these: compound 4.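

Compound 4 gives a limit and not a number in this assay: the limit of > 80000 nM in this assay, at which 1 of the 4 values shown sits. Until now this position had shown only chloro and bromo, which lie within the scatter of each other; hydroxy in place of chloro gives an at least 2.1-fold higher number from compound 1 to compound 4 (0.33 log units; beyond the scatter), the first exchange on this aromatic carbon to go beyond the scatter, while hydroxy in place of bromo gives an at least 1.4-fold higher number from compound 3 to compound 4 (0.15 log units; that floor lies within the scatter), whose floor does not yet separate the two groups. Within the data shown here, the change from 4-hydroxyphenyl to the pattern of compound 2 is also large, with 4-hydroxyphenyl in place of 3-chlorophenyl giving an at least 73-fold higher number from compound 2 to compound 4 (1.86 log units; beyond the scatter), so compound 2 remains the only low value in the set.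

The compounds shown leave open whether an amine or a carboxylic acid on this aromatic carbon would stay with the halogens or go with hydroxy. They also give only a floor for the hydroxy for bromo step, and they leave open whether hydroxy in place of chloro on the 3-chlorophenyl group of compound 2 would keep its low number.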